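The compounds below may be only part of what the source reports. "The series", "measured", "known", "first", "only" and "open" are said of these compounds alone.

All the compounds here share one core and differ only in the group on an amide-type nitrogen. In an ADME assay on HEp-2 cells (Homo sapiens) for cytotoxicity (a lower number here means that less compound is tolerated, a higher number that more compound is tolerated), compound 1 `Cc1ccc(NC(=O)[C@@H]2CCCN2S(=O)(=O)c2cccc3cccnc23)cc1` gives 31700 nM and compound 2 `Cc1ccc(C)c(NC(=O)[C@@H]2CCCN2S(=O)(=O)c2cccc3cccnc23)c1` gives 30900 nM. Compound 3 `COc1ccc(C)cc1NC(=O)[C@@H]1CCCN1S(=O)(=O)c1cccc2cccnc12` gives no exact number, only a limit of the assay: > 50000 nM. Compound 4 `Cc1cc(NC(=O)[C@@H]2CCCN2S(=O)(=O)c2cccc3cccnc23)n(C(C)(C)C)n1` has not been measured yet. It differs from compound 3 by a single change: 3-methyl-1-(tert-butyl)-1H-pyrazol-5-yl in place of 2-methoxy-5-methylphenyl on an amide-type nitrogen. In words, 3-methyl-1-(tert-butyl)-1H-pyrazol-5-yl takes the place of 2-methoxy-5-methylphenyl on the amide-type nitrogen.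

Among the compounds with values here, three measured steps bear on this change, as all of them alter the group at this same place. The first is a 1.0-fold lower number from compound 1 to compound 2 (0.01 log units; within the scatter). The other two, whose floors lie within the scatter, are an at least 1.5-fold higher number from compound 1 to compound 3 (0.19 log units; that floor lies within the scatter) and an at least 1.6-fold higher number from compound 2 to compound 3 (0.20 log units; that floor lies within the scatter). None of them brings in a five-membered aromatic ring, so they are only a loose guide here. On this evidence, no step beyond the scatter is expected in this assay, and the data point to no clear direction. The estimated change is an at least 1.2-fold lower number from compound 3 to compound 4 (0.09 log units; that floor lies within the scatter). The expected value for compound 4 is 40000 nM, with an estimated range from 20000 nM to 60000 nM.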

Compound 4, half-maximal cytotoxic concentration: > 50000 nM
Compound 4: only a limit was reported (the forecaster's own chance of this, stated with the estimate: 40%); middle value at least 1.2-fold (0.09 log units) away from the limit.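

In this assay compound 4 gives > 50000 nM, which is a limit of the assay and not an exact number. Set against the two compounds with exact numbers, the new result gives an at least 1.6-fold higher number from compound 2 to compound 4 (0.20 log units; that floor lies within the scatter) and an at least 1.5-fold higher number from compound 1 to compound 4 (0.19 log units; that floor lies within the scatter), so neither step shows a change beyond the scatter. What is new is that the group on the amide-type nitrogen need not be a six-membered aromatic ring of carbon only, since 3-methyl-1-(tert-butyl)-1H-pyrazol-5-yl, with its five-membered aromatic ring, reaches the same limit as 2-methoxy-5-methylphenyl, and the step between compound 3 and compound 4 therefore cannot be read: the limit of > 50000 nM in this assay, at which 2 of the 4 values shown sit.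

From the compounds shown here alone, how far compound 3 and compound 4 really differ stays open, as neither has an exact number here. Also open, going by these compounds, is whether a different group on the amide-type nitrogen, such as a plain butyl chain, a benzyl group or a pyridine ring, would give a number clearly different from those of compound 1 and compound 2.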